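The source may report more compounds than this note shows. Statements on the series, on what has been measured and on what is new or still open speak of the compounds shown alone.

Three related compounds have been measured in a functional assay on HeLa cells (Homo sapiens) for cytotoxicity, read by MTT assay, with a stated time of 48 h; on this read-out higher numbers stand for weaker inhibition and lower numbers for stronger inhibition. Compound 1 `CCCCCCCCCC(=O)N[C@H](C(=O)Nc1ccn([C@H]2O[C@@H](CO)[C@H](O)[C@H]2O)c(=O)n1)C(C)C` gives 4990 nM, the lowest of the three numbers. Compound 2 `CCCCCCCCCCCCCCCCCC(=O)N[C@H](C(=O)Nc1ccn([C@H]2O[C@@H](CO)[C@H](O)[C@H]2O)c(=O)n1)C(C)C` gives 13000 nM and compound 3 `CCCCCCCCCCCCCC(=O)N[C@H](C(=O)Nc1ccn([C@H]2O[C@@H](CO)[C@H](O)[C@H]2O)c(=O)n1)C(C)C` gives 26000 nM. Both differ from compound 1 only in the length of the saturated chain: there is a 2.6-fold higher number from compound 1 to compound 2 (0.42 log units; beyond the scatter) and a 5.2-fold higher number from compound 1 to compound 3 (0.72 log units; beyond the scatter), while the two chain-extended compounds lie within the scatter of each other, a 2.0-fold higher number from compound 2 to compound 3 (0.30 log units; within the scatter).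

Compound 4 `CCCCCCCCCC(=O)N[C@@H](CCSC)C(=O)Nc1ccn([C@H]2O[C@@H](CO)[C@H](O)[C@H]2O)c(=O)n1` leaves the chain untouched and alters a different place: 2-(methylsulfanyl)ethyl in place of isopropyl on a saturated chain carbon bound to an amide-type nitrogen and a carbonyl carbon. Within the data shown here, none of the measured steps touches this part of the molecule, so they give no direct guide to the size or direction of the change. The measured steps concern the chain only, and those steps are modest. With nothing pointing either way, no step beyond the scatter is expected. Compound 4 is therefore estimated at 5000 nM, with a range from 1800 nM to 14000 nM. That estimate means a 1.0-fold higher number from compound 1 to compound 4 (0.00 log units; within the scatter), which is expected to stay within the scatter.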

Compound 4, half-maximal inhibitory concentration: 3000 nM
Compound 4: middle estimate off by 1.7-fold (0.22 log units), on the high side; the range from low to high includes it.
By their numbers in this assay, from the lowest: compounds 4 and 1 (each within the scatter of the next); then compounds 2 and 3 (each within the scatter of the next).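

Swapping isopropyl for 2-(methylsulfanyl)ethyl on the saturated chain carbon bound to an amide-type nitrogen and a carbonyl carbon gives the first reading at this place, and in this assay it is a 1.7-fold lower number from compound 1 to compound 4 (0.22 log units; within the scatter), so compound 1 and compound 4 cannot be told apart. Unlike the chain-length steps, this change alters a different part of the molecule, and a group with a sulfur atom and a longer reach is accepted here without a change beyond the scatter. Nothing available explains this outcome.

Going by these compounds, it remains open whether the chain-length steps seen with isopropyl would carry over to compounds bearing 2-(methylsulfanyl)ethyl. It is also unknown how an amine or a carboxylic acid at this same place would behave.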